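Swapping the Amide Ring on a Shared Core

The compounds below may be only part of what the source reports. "The series", "measured", "known", "first", "only" and "open" are said of these compounds alone.

Three measured compounds share one core and differ only in the group on the carbonyl carbon. Compound 1 `COc1cc2c(cc1OC)C(CC(=O)N(C)C)CC2` carries a dimethylamino group there, and in a functional assay on the whole organism (strain Wistar) for inhibition, with Rattus norvegicus as the target, read by paw edema, with stated times of 60 min and 24 h, at a dose of 100 mg/kg by the oral route (a higher number here means more inhibition at the dose given (going by the name of the read-out), a lower number less inhibition), compound 1 gives 23.3%. Compound 2 `COc1cc2c(cc1OC)C(CC(=O)NC(C)C)CC2` carries an isopropylamino group; in this assay compound 2 gives 30%. Compound 3 `COc1cc2c(cc1OC)C(CC(=O)N1CCCC1)CC2` carries a pyrrolidin-1-yl group, and in this assay compound 3 gives 33.3%. Compound 3 holds the highest of the three numbers, yet the gaps are small: a number 3.3 percentage points higher from compound 2 to compound 3 (within the scatter) and a number 10 percentage points higher from compound 1 to compound 3 (within the scatter), both within the scatter, so the three numbers count as level and none of the three can be said to give a higher inhibition in this assay than another.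

Compound 4 `COc1cc2c(cc1OC)C(CC(=O)N1CCNCC1)CC2` has not yet been measured. It differs from compound 3 in one place: piperazin-1-yl in place of pyrrolidin-1-yl on a carbonyl carbon. Every step seen so far swaps one group on the carbonyl carbon for another, and each stayed within the scatter, including a number 6.7 percentage points higher from compound 1 to compound 2 (within the scatter) alongside the two steps above. Piperazin-1-yl brings a hydrogen-bond donor and acceptor that none of the measured groups has, and the data do not cover that; the expectation therefore rests only on those three steps. Compound 4 is expected to give about 30% in this assay, within a range from 15% to 45%. That corresponds to an expected step of a number 3.3 percentage points lower from compound 3 to compound 4 (within the scatter), not beyond the scatter.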

Compound 4, a percentage reported as inhibition, in the whole organism at one dose (the size of the read-out at that dose, not a potency): 65%
For compound 4 the middle estimate is 35 percentage points below the measured one; measured number outside the range, above it.
By their numbers in this assay, from the lowest: compounds 1, 2 and 3 (each within the scatter of the next); then compound 4.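

This place on the carbonyl carbon looked indifferent while dimethylamino, isopropylamino and pyrrolidin-1-yl were exchanged, but in this assay it does respond: piperazin-1-yl brings a number 31.7 percentage points higher from compound 3 to compound 4 (beyond the scatter) and also a number 35 percentage points higher from compound 2 to compound 4 (beyond the scatter) and a number 41.7 percentage points higher from compound 1 to compound 4 (beyond the scatter), which sets compound 4 clear of all three earlier compounds. The swap joins several differences at once, since a five-membered ring with 1 hetero atom gives way to a six-membered ring with 2 hetero atoms, and 1 hydrogen-bond donor and 1 hydrogen-bond acceptor enter where pyrrolidin-1-yl has 0 of each, so this single step cannot assign the gain to any one of them. No measurement available here accounts for the rise in inhibition.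

The compounds shown leave open whether the second ring nitrogen with its hydrogen matters or the six-membered ring alone, a question that piperidin-1-yl, with carbon at that place, and morpholin-4-yl, with oxygen there, would help to separate. They also leave open whether a substituent on that nitrogen, such as the methyl of 4-methylpiperazin-1-yl, would keep the higher number.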